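Ring-nitrogen substitution step from compound 1

The source may hold more compounds than are shown below. What is called first, only, known or untested is meant among the compounds shown, and "the series" means these compounds.

In a functional assay on MDA-MB-231 cells (Homo sapiens) for inhibition, read by MTT assay, with a stated time of 48 h (on this read-out higher numbers stand for weaker inhibition and lower numbers for stronger inhibition), compound 1 `COc1cc(-c2nc3cc(/C=C4\SC(=O)NC4=O)ccc3[nH]2)cc(OC)c1OC` gives 6830 nM. Compound 2 `COc1ccc(-c2nc3cc(/C=C4\SC(=O)NC4=O)ccc3[nH]2)cc1OC` gives 13600 nM in this assay. The change from compound 1 to compound 2 is hydrogen in place of methoxy on an aromatic carbon, and the step is a 2.0-fold higher number from compound 1 to compound 2 (0.30 log units; within the scatter). Of the two numbers compound 1 carries the smaller, but the gap to compound 2 lies within the scatter and so separates nothing.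

Compound 3 `COc1cc(-c2nc3cc(/C=C4\SC(=O)N(CC(=O)N5CCCC5)C4=O)ccc3[nH]2)cc(OC)c1OC` differs from compound 1 by ((pyrrolidin-1-yl)carbonyl)methyl in place of hydrogen on an amide-type nitrogen in a ring. Among the measured compounds shown here, no measured step touches the amide-type nitrogen in the ring; the single measured step, a 2.0-fold higher number from compound 1 to compound 2 (0.30 log units; within the scatter), concerns an aromatic methoxy and lies within the scatter, so it does not bear on this change. No step beyond the scatter is therefore expected in this assay. The estimate for compound 3 is 6000 nM, with a range from 2000 nM to 20000 nM, which means an expected step of a 1.1-fold lower number from compound 1 to compound 3 (0.06 log units; within the scatter).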

Compound 3, half-maximal inhibitory concentration: 2880 nM
The estimate for compound 3 lay 2.1-fold (0.32 log units) above the measured number; the range from low to high includes it.
By their numbers in this assay, from the lowest: compound 3; then compounds 1 and 2 (each within the scatter of the next).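

The amide-type nitrogen in the ring accepts a substituent in this assay: ((pyrrolidin-1-yl)carbonyl)methyl in place of hydrogen gives a 2.4-fold lower number from compound 1 to compound 3 (0.38 log units; beyond the scatter), a modest step. This is the only step in the series shown beyond the scatter, and the earlier pair, which differs only at an aromatic methoxy, said nothing about this nitrogen. Nothing measured here accounts for the step.

From the compounds shown here alone, with only one substituent at this nitrogen, it remains open whether the step follows from the pyrrolidine ring, the carbonyl or the loss of the amide hydrogen; a plain methyl, a carboxylic acid or an open-chain amine at this nitrogen would help separate these. Also open, going by these compounds, is whether the same substituent gives a similar step on the core of compound 2.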